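A few compounds are considered here, and "the series" means these few. Any claim that something is new, unique, unknown or untested is made for them only; others in the source may bear on it.

Of the compounds shown here, three of one family have been measured in a functional assay on HCT-116 cells (Homo sapiens) for inhibition, read by MTT assay, with a stated time of 48 h; on this read-out higher numbers stand for weaker inhibition and lower numbers for stronger inhibition. Compound 1 `COc1ccc(CNc2cc(OC)c(OC)c(OC)c2)cc1[N+](=O)[O-]` gives 18200 nM, compound 3 `COc1ccc(CNc2cc(OC)c(OC)c(OC)c2)cc1F` gives 32200 nM, and compound 2 `COCC(=O)N(Cc1ccc(OC)c(O)c1)c1cc(OC)c(OC)c(OC)c1` gives 230 nM. Within the data shown here, the only single-point step among them, a 1.8-fold higher number from compound 1 to compound 3 (0.25 log units; within the scatter), leaves the two values indistinguishable. Compound 2 stands apart: it holds the lowest number of the three, so it is the strongest inhibitor here, far below compound 1 and further still below compound 3.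

Compound 4 `COc1ccc(CN(C(=O)C(C)C)c2cc(OC)c(OC)c(OC)c2)cc1O` is not yet measured. It differs from compound 2 by isopropyl in place of methoxymethyl on a carbonyl carbon. Among the measured compounds shown here, no measured step touches this part of the molecule; the one recorded step concerns a substituent on an aromatic carbon, not the group on the carbonyl carbon, so it gives no direct guide. With nothing to suggest a large movement, the expected step from compound 2 to compound 4 is a 1.3-fold higher number from compound 2 to compound 4 (0.12 log units; within the scatter), lying within the scatter. On that basis compound 4 is estimated at 300 nM in this assay, expected to fall between 100 nM and 1000 nM.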

Compound 4, half-maximal inhibitory concentration: 310 nM
Beside the measured number, compound 4's estimate is 1.0-fold (0.01 log units) below it, within the range that was stated.
By their numbers in this assay, from the lowest: compounds 2 and 4 (each within the scatter of the next); then compounds 1 and 3 (each within the scatter of the next).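

In this assay, the first step recorded on this carbonyl carbon is a 1.3-fold higher number from compound 2 to compound 4 (0.13 log units; within the scatter), so replacing methoxymethyl with isopropyl leaves the two compounds indistinguishable. The oxygen of methoxymethyl can therefore give way to carbon, in a group with the same number of heavy atoms, without a change beyond the scatter, although this holds only for this one pair. Nothing supplied here explains why the two groups read alike.

From the compounds shown here alone, it remains open whether this carbonyl carbon would tolerate a longer chain, such as n-butyl, or a group of another kind, such as an amine or a carboxylic acid. The large gap between these two compounds and compounds 1 and 3 also cannot be assigned to any single group, since those pairs differ in more than one place.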